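A few compounds are considered here, and "the series" means these few. Any claim that something is new, unique, unknown or untested is made for them only; others in the source may bear on it.

Measured compounds:
compound 1, `CCCCCCCCCCC[C@@H](C[C@@H]1OC(=O)[C@H]1CCCCCC)OC(=O)[C@H](C)NC=O`, 43 nM
compound 2, `CCCCCCCCCCC[C@@H](C[C@@H]1OC(=O)[C@H]1CCCCCC)OC(=O)[C@@H](NC(C)=O)C(C)CC`, 430 nM

Within the data shown here, in an assay on COS-7 cells for inhibition of diacylglycerol lipase-alpha (Homo sapiens), read by scintillation counting (on this read-out higher numbers stand for weaker inhibition and lower numbers for stronger inhibition), the only measured step is a 10-fold higher number from compound 1 to compound 2 (1.00 log units; beyond the scatter). Compound 2 therefore holds the higher of the two numbers, and compound 1 the lower.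

Compound 3, `CCCCCCCCCCC[C@@H](C[C@@H]1OC(=O)[C@H]1CCCCCC)OC(=O)[C@@H]1CCC(=O)N1`, is not yet measured. Relative to compound 2 the change is 5-oxopyrrolidin-2-yl in place of 1-acetamido-2-methylbutyl on a carbonyl carbon. Among the measured compounds shown here, the one measured step bears on it only indirectly: from compound 1 to compound 2 a larger group entered on the same carbonyl carbon and the number rose, whereas compound 3 carries the smaller group, now closed into a five-membered ring. For the measured compounds named here, no measured step tests a ring group at this carbonyl carbon, so the expectation is loose. On this basis a lower number than compound 2 is expected, roughly a 3.6-fold lower number from compound 2 to compound 3 (0.55 log units; beyond the scatter), though the ring leaves it uncertain. Compound 3 is estimated at 120 nM, within 30 nM to 500 nM.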

Compound 3, half-maximal inhibitory concentration: 100 nM
Compound 3: middle estimate off by 1.2-fold (0.08 log units), on the high side; the measured number falls inside the stated range.
By their numbers in this assay, from the lowest: compound 1; then compound 3; then compound 2.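

In this assay, a ring group is accepted on this carbonyl carbon: 5-oxopyrrolidin-2-yl in place of 1-acetamido-2-methylbutyl gives a 4.3-fold lower number from compound 2 to compound 3 (0.63 log units; beyond the scatter). The ring does not match the open group of compound 1, however, with a 2.3-fold higher number from compound 1 to compound 3 (0.37 log units; beyond the scatter), so across the three compounds the numbers rise with the size of the group and none goes against that order. Nothing available here gives a reason for either step.

Whether closure into the ring or the smaller size alone accounts for the lower number than compound 2 stays open, since the two changes come together in compound 3. Also open, from the compounds shown here alone, is how a free amine or a carboxylic acid would read in place of 5-oxopyrrolidin-2-yl on this carbonyl carbon.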